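The source may hold more compounds than are shown below. What is called first, only, known or untested is meant among the compounds shown, and "the series" means these compounds.

Working notes on the series. Within the data shown here, compound 3 `O=c1[nH]/c(=N\OCCCc2ccc([N+](=O)[O-])cc2)ccn1[C@@H]1O[C@H](COP(=O)(O)OP(=O)(O)OP(=O)(O)O)[C@@H](O)[C@H]1O` stands second highest of the three numbers so far in a functional assay on 1321-N1 cells for agonist activity at P2Y purinoceptor 2 (Homo sapiens), read by scintillation counting and inositol phosphate accumulation; on this read-out lower numbers stand for an effect already at smaller amounts and higher numbers for an effect only at larger amounts of compound; compound 3 gives 458 nM. Its nearest neighbour is compound 1 `O=c1[nH]/c(=N\OCCCc2ccc(F)cc2)ccn1[C@@H]1O[C@H](COP(=O)(O)OP(=O)(O)OP(=O)(O)O)[C@@H](O)[C@H]1O`, which in this assay gives 547 nM; furthest is compound 2 `O=c1[nH]/c(=N\OCCCc2cccc(I)c2)ccn1[C@@H]1O[C@H](COP(=O)(O)OP(=O)(O)OP(=O)(O)O)[C@@H](O)[C@H]1O`, which in this assay gives 325 nM. Every measured step lies within the scatter: a 1.2-fold lower number from compound 1 to compound 3 (0.08 log units; within the scatter); a 1.7-fold lower number from compound 1 to compound 2 (0.23 log units; within the scatter); a 1.4-fold higher number from compound 2 to compound 3 (0.15 log units; within the scatter).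

Compound 4 `O=c1[nH]/c(=N\OCCCc2ccsc2)ccn1[C@@H]1O[C@H](COP(=O)(O)OP(=O)(O)OP(=O)(O)O)[C@@H](O)[C@H]1O` changes the group on the chain: thiophen-3-yl in place of 4-nitrophenyl on a saturated chain carbon, three bonds along the chain from an oxygen. Among the measured compounds shown here, the steps that bear on it are the two earlier exchanges of the aromatic group at the same place, a 1.7-fold lower number from compound 1 to compound 2 (0.23 log units; within the scatter) and a 1.4-fold higher number from compound 2 to compound 3 (0.15 log units; within the scatter), together with the substituent exchange a 1.2-fold lower number from compound 1 to compound 3 (0.08 log units; within the scatter), none of them beyond the scatter. Three aromatic groups of different size and substitution have given numbers in a narrow band, so no step beyond the scatter is expected in this assay in either direction; the expected step is a 1.0-fold lower number from compound 3 to compound 4 (0.01 log units; within the scatter). For compound 4 the estimate in this assay is 450 nM, with a range from 150 nM to 1400 nM. For the measured compounds named here, no compound with a five-membered ring bearing a hetero atom has been measured here, and the range is kept wider than the measured band.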

Compound 4, half-maximal effective concentration: 103 nM
Beside the measured number, compound 4's estimate is 4.4-fold (0.64 log units) above it; measured number below the stated range.
By their numbers in this assay, from the lowest: compound 4; then compounds 2, 3 and 1 (each within the scatter of the next).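

In this assay, the group on a saturated chain carbon, three bonds along the chain from an oxygen, now gives steps beyond the scatter: a 4.4-fold lower number from compound 3 to compound 4 (0.65 log units; beyond the scatter), a 3.2-fold lower number from compound 2 to compound 4 (0.50 log units; beyond the scatter) and a 5.3-fold lower number from compound 1 to compound 4 (0.73 log units; beyond the scatter). The exchanges among the three substituted phenyl groups all stayed within the scatter, so this position does respond to the group it carries, and thiophen-3-yl gives the lowest number of the four compounds. Nothing measured here accounts for this difference.

Since thiophen-3-yl differs from those groups in ring size, in its sulfur and in carrying no further substituent, these features remain unseparated; plain phenyl, furyl and pyridyl would bear on that. From the compounds shown here alone, whether the step holds with another chain length also remains open, for example with 2-(thiophen-3-yl)ethyl.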